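Amide nitrogen substituent swap on a shared triazole-free core

This account rests on a few compounds, and the source may have more. Where it says the series, first, only, none or still open, it means among the compounds named here.

Compound 1 `COc1cc(-c2nnc(SCC(=O)c3ccc(F)cc3)n2N)cc(OC)c1OC`: 20900 nM
Compound 2 `COc1cc(-c2nnc(SCC(=O)c3cccc(Br)c3)n2N)cc(OC)c1OC`: 77500 nM
Compound 3 `COc1cc(-c2nnc(SCC(=O)Nc3ccccc3F)n2N)cc(OC)c1OC`: 38200 nM

In a functional assay on HeLa cells (Homo sapiens) for antiproliferative activity, read by MTT assay, with a stated time of 48 h (a higher number here means a weaker inhibitor, a lower number a stronger inhibitor), compound 3 gives the second highest of the three numbers; it sits near compound 1 and apart from compound 2. Compound 4 `COc1ccc(CNC(=O)CSc2nnc(-c3cc(OC)c(OC)c(OC)c3)n2N)cc1OC` differs from compound 3 by 3,4-dimethoxybenzyl in place of 2-fluorophenyl on an amide-type nitrogen. For the measured compounds named here, none of the measured steps touches that nitrogen: a 3.7-fold higher number from compound 1 to compound 2 (0.57 log units; beyond the scatter) and a 2.0-fold lower number from compound 2 to compound 3 (0.31 log units; beyond the scatter) concern groups on the carbonyl carbon, and a 1.8-fold higher number from compound 1 to compound 3 (0.26 log units; within the scatter) stays within the scatter. Nothing here therefore points to a change beyond the scatter, and the step of a 1.1-fold lower number from compound 3 to compound 4 (0.04 log units; within the scatter) is an expectation carrying wide uncertainty. Compound 4 is estimated at 35000 nM, with a range from 10000 nM to 120000 nM.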

Compound 4, half-maximal inhibitory concentration: > 100000 nM
Compound 4 gave a limit, no number; the forecaster's own chance of this, stated with the estimate: 10%; middle value at least 2.8-fold (0.45 log units) away from the limit.
By their numbers in this assay, from the lowest: compounds 1 and 3 (each within the scatter of the next); then compound 2. At a limit, above all of these: compound 4.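

For the compounds shown here, this is the first measured change on the amide-type nitrogen itself. In this assay, 3,4-dimethoxybenzyl in place of 2-fluorophenyl gives an at least 2.6-fold higher number from compound 3 to compound 4 (0.41 log units; beyond the scatter), so the group on this nitrogen does matter for the read-out. Compound 4 gave a limit and not a number, and the size of this step is only a lower bound because the read-out stops there: the limit of > 100000 nM in this assay, at which 1 of the 4 values shown sits.

The compounds shown leave open whether the benzyl link or the two methoxy groups carry this change. A plain benzyl without methoxy groups, or a small methyl, on this nitrogen would help separate the two.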